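From Ethyl to Isopropyl: Compound 3 to Compound 4

The source may hold more compounds than are shown below. What is called first, only, known or untested is meant among the compounds shown, and "the series" means these compounds.

Of the compounds shown here, three have been measured in a functional assay on the whole organism with Canis familiaris (Canis lupus familiaris) as the target, at a dose of 8 mg/kg by the oral route; a lower number here means a weaker effect, a higher number a stronger effect of the compound at the dose given. Compound 1 `Cc1cc(OCc2ccccc2)c2nc(C)c(C)n2c1` gives 71%, compound 2 `Cc1ccn2c(C)c(C)nc2c1OCc1ccccc1` gives 35%, and compound 3 `CCc1nc2c(OCc3ccccc3)cccn2c1N` gives 59%. Compound 3 thus stands second highest of the three: its nearest neighbour is compound 1, which lies higher by more than the scatter, and its furthest is compound 2, which lies lower by more than the scatter.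

Compound 4 `CC(C)c1nc2c(OCc3ccccc3)cccn2c1N` differs from compound 3 by methyl in place of hydrogen on a saturated chain carbon bound to an aromatic carbon and a saturated chain carbon; read one bond further out, ethyl becomes isopropyl. For the measured compounds named here, no pair of measured compounds shows this change, so there is no measured step to lean on, and nothing here suggests a move in this assay beyond the scatter in either direction. Compound 4 is therefore expected to give 55%, with a range from 30% to 75%. The step of a number 4 percentage points lower from compound 3 to compound 4 (within the scatter) is expected to be small.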

Compound 4, a percentage reported as inhibition, in the whole organism at one dose (the size of the read-out at that dose, not a potency): 0%
Compound 4: middle estimate off by 55 percentage points, on the high side; the whole stated range lies above it.
By their numbers in this assay, from the lowest: compound 4; then compound 2; then compound 3; then compound 1.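

In this assay, for the compounds shown here, the single change from ethyl to isopropyl gives a number 59 percentage points lower from compound 3 to compound 4 (beyond the scatter) and so shows that this position is far from indifferent: one added methyl on this saturated chain carbon is enough to take the read-out from a mid-range value down to the lowest of the series. No data shown here account for this drop.

The compounds shown leave open whether the loss follows from branching at this carbon as such or from the added carbon alone. A straight propyl chain or a cyclopropyl group in this place would separate the two.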